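Three Measured Amides and One Expected Value

The source may hold more compounds than are shown below. What is called first, only, known or untested is meant among the compounds shown, and "the series" means these compounds.

Compound 1, `COc1cc(C2OC(c3ccc(N(C)C)cc3)=NN2C(C)=O)cc(OC)c1OC`: in a functional assay on NCI-H460 cells (Homo sapiens) (on this read-out higher numbers stand for an effect only at larger amounts of compound and lower numbers for an effect already at smaller amounts), compound 1 gives 0.044 uM.
Compound 2, `COc1cc(C2OC(c3ccc(N(C)C)cc3)=NN2C=O)cc(OC)c1OC`: in this assay compound 2 gives 0.12 uM.
Compound 3, `COc1cc(C2OC(c3ccc(N(C)C)cc3)=NN2C(=O)CNC=O)cc(OC)c1OC`: in this assay compound 3 gives 0.04 uM.

Compound 4, `COc1cc(C2OC(c3ccc(N(C)C)cc3)=NN2C(=O)CNC(C)=O)cc(OC)c1OC`, is the one not yet measured. It differs from compound 3 by methyl in place of hydrogen on a carbonyl carbon. The same change has already been made once in this set: compound 1 differs from compound 2 by methyl in place of hydrogen on a carbonyl carbon, and in this assay that step gave a 2.7-fold lower number from compound 2 to compound 1 (0.44 log units; beyond the scatter). The two places are not identical, though. In the measured pair the carbonyl carbon's other neighbour is an amide-type nitrogen in a ring, whereas in compound 4 it is an amide-type nitrogen outside a ring, so the change is the same kind of change rather than the same one.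

The cores of compound 2 and compound 3 differ by (formylamino)methyl in place of hydrogen on a carbonyl carbon, a change that gave a 3.0-fold lower number from compound 2 to compound 3 (0.48 log units; beyond the scatter). Between compound 1 and compound 3 the step of a 1.1-fold lower number from compound 1 to compound 3 (0.04 log units; within the scatter) lies within the scatter, so the longer chain on its own brought no counted gain.

For compound 4 a step of a 1.3-fold lower number from compound 3 to compound 4 (0.12 log units; within the scatter) is expected, smaller than the measured one, since the step of a 1.1-fold lower number from compound 1 to compound 3 (0.04 log units; within the scatter) suggests this part of the molecule tolerates additions without much movement in the number. Compound 4 is therefore estimated at 0.03 uM, with the likely range running from 0.012 uM to 0.08 uM.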

Compound 4, concentration for half-maximal effect: 0.48 uM
Compound 4: middle estimate off by 16-fold (1.20 log units), on the low side, and the stated range ends below it.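

In this assay, the change from hydrogen to methyl on a carbonyl carbon did not carry over from one core to the other, and the two steps run in opposite directions: the same change on two cores in this assay, a 2.7-fold lower number (0.44 log units; beyond the scatter) from compound 2 to compound 1 and a 12-fold higher number (1.08 log units; beyond the scatter) from compound 3 to compound 4, 33-fold (1.51 log units) apart, beyond the scatter of two such steps On the core of compound 3 the change gives a 12-fold higher number from compound 3 to compound 4 (1.08 log units; beyond the scatter), and the other two routes to compound 4 point the same way, with an 11-fold higher number from compound 1 to compound 4 (1.04 log units; beyond the scatter) and a 4.0-fold higher number from compound 2 to compound 4 (0.60 log units; beyond the scatter). This shows that the earlier step cannot be transferred as a rule in this series, but with one pair on each core it does not show how any other core would respond, nor whether the different surroundings of the carbonyl, an amide-type nitrogen in a ring in one pair and outside a ring in the other, account for the reversal.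

The compounds shown leave open whether the higher number belongs to acetamido in particular or would also appear with a longer acyl group such as propionamido or with a benzamido group on the same chain. They also leave open what a free amine would give in place of formylamino, and whether a methyl on the amide nitrogen of compound 3 would move the number at all.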